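The source may hold more compounds than are shown below. What is called first, only, known or untested is meant among the compounds shown, and "the series" means these compounds.

Measured compounds:
Compound 1, `COc1cc(-c2cc(/C=C/C(=O)c3ccc(N)cc3)[nH]n2)cc(OC)c1OC`: 3920 nM
Compound 2, `COc1ccc(-c2cc(/C=C/C(=O)c3ccc(N)cc3)[nH]n2)cc1OC`: 9670 nM
Compound 3, `COc1cc(C(=O)/C=C/c2cc(-c3cc(OC)c(OC)c(OC)c3)n[nH]2)cc(OC)c1OC`: 2890 nM

All three were run in a functional assay on HOP-62 cells (Homo sapiens) for inhibition, read by sulforhodamine B assay, with a stated time of 48 h; on this read-out higher numbers stand for weaker inhibition of growth and lower numbers for stronger inhibition of growth. In this assay compound 1 gives 3920 nM and compound 2 gives 9670 nM. The pair differs in one place: hydrogen in place of methoxy on an aromatic carbon. The step is a 2.5-fold higher number from compound 1 to compound 2 (0.39 log units; beyond the scatter). Compound 3 gives 2890 nM in this assay; the difference between the core of compound 3 and the core of compound 1 is not broken down here. Against compound 1 the number for compound 3 is within the scatter; against compound 2 it is beyond it.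

Compound 4, `COc1ccc(-c2cc(/C=C/C(=O)c3cc(OC)c(OC)c(OC)c3)[nH]n2)cc1OC`, has not yet been measured. It differs from compound 3 in one place: hydrogen in place of methoxy on an aromatic carbon. The surroundings of the place are described in the same words as for the change from compound 1 to compound 2, so this is the same change, seen for the second time in the series. For the measured compounds named here, the only guide to its size is the step of a 2.5-fold higher number from compound 1 to compound 2 (0.39 log units; beyond the scatter), which rests on a single pair. Carrying that step over, the expected step in this assay is a 2.4-fold higher number from compound 3 to compound 4 (0.38 log units; beyond the scatter). Compound 4 is therefore estimated at 7000 nM, with a range of 3500 nM to 14000 nM, the width of the range reflecting that one pair alone supports the transfer.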

Compound 4, concentration for total growth inhibition: 3580 nM
Compound 4: middle estimate off by 2.0-fold (0.29 log units), on the high side; low and high end bracket the measured number.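

In this assay, hydrogen in place of methoxy on an aromatic carbon gives a 1.2-fold higher number from compound 3 to compound 4 (0.09 log units; within the scatter). Set beside the earlier step, the two readings cannot be told apart: the same change on two cores in this assay, a 2.5-fold higher number (0.39 log units; beyond the scatter) from compound 1 to compound 2 and a 1.2-fold higher number (0.09 log units; within the scatter) from compound 3 to compound 4, 2.0-fold (0.30 log units) apart, within the scatter of two such steps. For the compounds shown here, the series therefore gives no evidence that the change depends on the core, but it does not establish one size that carries from core to core either, since only two pairs are available, one step lies beyond the scatter and the other within it, and nothing here accounts for the gap between them.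

The compounds shown hold only methoxy or hydrogen at this place, so the outcome with a hydroxyl group, a fluorine atom or an ethoxy group there remains open. Also open, going by these compounds, is whether the step would hold on a further core, such as one with a carboxylic acid where compound 1 carries its amine, and whether it would hold in any cell line other than the one used in this assay.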